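The compounds below may be only part of what the source reports. "The series", "measured", "known", "first", "only" and "open" are said of these compounds alone.

Three compounds share one core and differ only in the group carried on an oxygen of that core. Compound 1 `CN(C)C(=O)/C=C/CN1CC(Oc2ccc(Oc3c(-c4ccc(F)cc4)sc4cc(O)ccc34)cc2)C1` bears a 1-(3-(dimethylcarbamoyl)prop-2-en-1-yl)azetidin-3-yl group, and in a functional assay on MCF7 cells (Homo sapiens) for antiproliferative activity, read by CCK-8 assay, with a stated time of 48 h (on this read-out lower numbers stand for stronger inhibition and higher numbers for weaker inhibition), compound 1 gives 22300 nM. Compound 2 `CN(C)C(=O)/C=C/CNCCOc1ccc(Oc2c(-c3ccc(F)cc3)sc3cc(O)ccc23)cc1` carries the open-chain 2-((3-(dimethylcarbamoyl)prop-2-en-1-yl)amino)ethyl group in its place, and in this assay compound 2 gives 13800 nM; that change is a 1.6-fold lower number from compound 1 to compound 2 (0.21 log units; within the scatter). Compound 3 `C=C(C)C(=O)N1CC(Oc2ccc(Oc3c(-c4ccc(F)cc4)sc4cc(O)ccc34)cc2)C1` keeps the azetidine ring but carries (1-methylethenyl)carbonyl on the ring nitrogen. In this assay compound 3 reaches only a limit of the assay, > 25000 nM, so no number is known for it. The steps of an at least 1.1-fold higher number from compound 1 to compound 3 (0.04 log units; that floor lies within the scatter) and an at least 1.8-fold higher number from compound 2 to compound 3 (0.25 log units; that floor lies within the scatter) are therefore floors, not measured sizes.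

Compound 4 `C/C=C/C(=O)N1CC(Oc2ccc(Oc3c(-c4ccc(F)cc4)sc4cc(O)ccc34)cc2)C1` differs from compound 3 in one place: prop-1-en-1-yl in place of 1-methylethenyl on a carbonyl carbon. Going by the values given here, no measured step covers a rearrangement of this kind, so the expectation rests on compound 3 alone. The expected step of a number no higher from compound 3 to compound 4 (the limit leaves the size open) is none beyond the scatter. Compound 4 is estimated at 25000 nM, within a range from 12000 nM to 50000 nM, and may again reach only the limit.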

Compound 4, half-maximal inhibitory concentration: 28000 nM
The estimate for compound 4 lay 1.1-fold (0.05 log units) below the measured number; low and high end bracket the measured number.
By their numbers in this assay, from the lowest: compounds 2, 1 and 4 (each within the scatter of the next, the first and the last beyond it).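

In this assay, going by these compounds alone, compound 4 gives 28000 nM and so supplies the first actual number for a group joined through a carbonyl to the azetidine nitrogen. That number sits close to the amine-linked compound 1 (a 1.3-fold higher number from compound 1 to compound 4 (0.10 log units; within the scatter)), but it separates, modestly, from the open-chain compound 2 (a 2.0-fold higher number from compound 2 to compound 4 (0.31 log units; beyond the scatter)), the only gap among these three numbers that clears the scatter. The step from compound 3 to compound 4 cannot be read, because compound 3 stands at a limit of the assay: the limit of > 25000 nM in this assay, at which 1 of the 4 values shown sits.

Going by these compounds, whether moving the double bond within the three-carbon group matters at all therefore stays open. So does how a saturated propyl group or a plain ethenyl group on the same carbonyl would read.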